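A few compounds are considered here, and "the series" means these few. Any claim that something is new, unique, unknown or untested is made for them only; others in the source may bear on it.

In a functional assay on MCF7 cells (Homo sapiens) for antiproliferative activity, read by MTT assay, with a stated time of 72 h (on this read-out higher numbers stand for weaker inhibition and lower numbers for stronger inhibition), compound 1 `COc1cccc(N2C(=O)COc3ccc(-c4cccc(NS(=O)(=O)c5ccc(F)cc5)c4)cc32)c1` gives > 40000 nM which is a limit and not a number. Going by the values given here, compound 2 `Cc1ccc(N2C(=O)COc3ccc(-c4cccc(NS(=O)(=O)c5ccc(F)cc5)c4)cc32)cc1` gives 32100 nM as the only actual number so far, so there is no second firm value to rank it against. Compound 3 `O=C1COc2ccc(-c3cccc(NS(=O)(=O)c4ccc(F)cc4)c3)cc2N1c1ccc(F)cc1` differs from compound 2 in one place, with fluoro in place of methyl on an aromatic carbon para to a large group, which turns 4-methylphenyl into 4-fluorophenyl. One measured step bears on this same group on the amide-type nitrogen, and an at least 1.2-fold lower number from compound 1 to compound 2 (0.09 log units; that floor lies within the scatter) does not go beyond the scatter, so a swap there has not yet shown a real effect. No change beyond the scatter is expected in this assay in either direction. The estimated step of a 1.1-fold higher number from compound 2 to compound 3 (0.04 log units; within the scatter) is therefore small. For compound 3 the estimate is 35000 nM with an expected range from 16000 nM to 60000 nM and a reading of only the limit would not surprise.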

Compound 3, half-maximal inhibitory concentration: > 40000 nM
Compound 3: only a limit was reported (the forecaster's own chance of this, stated with the estimate: 40%); middle value at least 1.1-fold (0.05 log units) from the limit.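

In this assay, going by these compounds alone, fluoro in place of methyl on the aromatic carbon para to a large group gives an at least 1.2-fold higher number from compound 2 to compound 3 (0.09 log units; that floor lies within the scatter), so a second swap on this ring has produced no step known to go beyond the scatter, though its true size remains unknown. Compound 3 gives only a limit, and the step from compound 1 to compound 3 cannot be read, as both values are limits. For this small set, the ring on the amide-type nitrogen has so far yielded just one actual number, and the rest stop at the same ceiling: the limit of > 40000 nM in this assay, at which 2 of the 3 values shown sit.

From the compounds shown here alone, it remains open whether any group at this para carbon can bring the number clearly down. An amine or a carboxylic acid there, or a plain phenyl ring with no added group, would test this on the same core.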